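Triazolethione series: fluorophenyl placement and cytotoxicity

The source may hold more compounds than are shown below. What is called first, only, known or untested is meant among the compounds shown, and "the series" means these compounds.

Measured compounds:
compound 1 `CS(=O)(=O)c1ccc(Cc2n[nH]c(=S)n2/N=C/c2c(F)cccc2Cl)cc1` — 77.3%
compound 2 `CS(=O)(=O)c1ccc(Cc2n[nH]c(=S)n2/N=C/c2ccc(-c3ccccc3)cc2)cc1` — 69.5%
compound 3 `CS(=O)(=O)c1ccc(Cc2n[nH]c(=S)n2/N=C/c2ccc(F)cc2)cc1` — 57.8%

In a functional assay on HeLa cells (Homo sapiens) for cytotoxicity, read by MTT assay, with a stated time of 48 h, tested at 100 uM (a higher number here means a stronger effect of the compound at the concentration tested, a lower number a weaker effect), compound 3 gives the lowest of the three numbers; the nearest is compound 2 with 69.5% and the furthest is compound 1 with 77.3%, both steps beyond the scatter.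

Compound 4 `CS(=O)(=O)c1ccc(Cc2n[nH]c(=S)n2/N=C/c2ccccc2F)cc1` differs from compound 3 as follows: 2-fluorophenyl in place of 4-fluorophenyl on a carbon with a double bond to nitrogen.

The step of a number 19.5 percentage points lower from compound 1 to compound 3 (beyond the scatter) bears most directly on this change, since compound 1 also carries fluorine on the aromatic ring attached to the carbon with a double bond to nitrogen, though together with chlorine. The step of a number 11.7 percentage points lower from compound 2 to compound 3 (beyond the scatter) concerns the same position of the series. Compound 4 is therefore expected to sit above compound 3, an estimated a number 7.2 percentage points higher from compound 3 to compound 4 (within the scatter), but short of compound 1. The estimate for compound 4 is 65%, with a range from 50% to 80%.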

Compound 4, a percentage reported as activity, at one concentration (the size of the read-out at that concentration, not a potency): 28.1%
Estimate against measurement, compound 4: 36.9 percentage points above; the measured number lies below the stated range.
By their numbers in this assay, from the lowest: compound 4; then compound 3; then compounds 2 and 1 (each within the scatter of the next).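

With the same atoms joined differently, 2-fluorophenyl in place of 4-fluorophenyl on a carbon with a double bond to nitrogen comes with a number 29.7 percentage points lower from compound 3 to compound 4 (beyond the scatter) in this assay so the place of the fluorine on this ring matters by itself. Hydrogen in place of chloro on an aromatic carbon comes with a number 49.2 percentage points lower from compound 1 to compound 4 (beyond the scatter) so fluorine on this ring does not by itself give a high number. No measurement at hand accounts for either step.

Open, on these data alone, is whether an amine or a methoxy group in place of fluoro on this ring would lift the number. Also open, as far as these compounds go, is whether chloro without fluoro on this ring would give a high number.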